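Adding a second chloro to compound 3

The source may report more compounds than this note shows. Statements on the series, on what has been measured and on what is new or still open speak of the compounds shown alone.

Of the compounds shown here, three built on a shared core have been read in a functional assay on THP-1 cells (Homo sapiens) for cytotoxicity, read by MTT assay, with a stated time of 24 h; on this read-out lower numbers stand for stronger inhibition and higher numbers for weaker inhibition. Compound 1 `CN1C/C(=C\c2ccc(C(C)(C)C)cc2)C(=O)/C(=C/c2ccccc2F)C1` gives 13400 nM, compound 2 `COc1cc(/C=C2\CN(C)C/C(=C\c3ccc(F)cc3)C2=O)cc(OC)c1` gives 5040 nM, and compound 3 `COc1cc(/C=C2\CN(C)C/C(=C\c3ccc(Cl)cc3)C2=O)cc(OC)c1` gives 5860 nM. Compound 3 thus lies within the scatter of compound 2, while the number for compound 1 stands higher than both. Compound 4 `COc1cc(/C=C2\CN(C)C/C(=C\c3ccc(Cl)c(Cl)c3)C2=O)cc(OC)c1` has not yet been measured. It differs from compound 3 by a single change, chloro in place of hydrogen on an aromatic carbon, ortho to a chloro group, which turns 4-chlorophenyl to 3,4-dichlorophenyl. Among the measured compounds shown here, only one measured step bears on this, namely a 1.2-fold higher number from compound 2 to compound 3 (0.07 log units; within the scatter), where chloro replaces fluoro. That step exchanges one group for another and adds none, so it is only an indirect guide. No change beyond the scatter is therefore expected in this assay, and no direction is firmly indicated. The expected step is a 1.2-fold lower number from compound 3 to compound 4 (0.07 log units; within the scatter). Compound 4 is estimated at 5000 nM, with an expected range of 2300 nM to 11000 nM.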

Compound 4, half-maximal inhibitory concentration: 3260 nM
Compound 4: the middle estimate sits 1.5-fold (0.19 log units) above what was measured; low and high end bracket the measured number.
By their numbers in this assay, from the lowest: compounds 4, 2 and 3 (each within the scatter of the next); then compound 1.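

In this assay, among the compounds shown here, the added chloro, ortho to a chloro group on the aromatic ring, gives a 1.8-fold lower number from compound 3 to compound 4 (0.25 log units; within the scatter) and stays within the scatter, so this is the first direct reading of a group entering at this position, and the position takes a second chloro with no change that can be told apart from repeat measurements. The wider exchange of 4-fluorophenyl for 3,4-dichlorophenyl gives a 1.5-fold lower number from compound 2 to compound 4 (0.19 log units; within the scatter) and also stays within the scatter, so neither step separates the three compounds that carry this ring and these substituents. Nothing measured here bears on the cause of these small steps.

Going by these compounds, whether an amine or a carboxylic acid in place of this second chloro would move the number beyond the scatter remains open. Also open, on these data alone, is whether a step seen on THP-1 cells would hold in any other cell line.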